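Extending the cyclohexyl tail of compound 1

A few compounds are considered here, and "the series" means these few. Any claim that something is new, unique, unknown or untested is made for them only; others in the source may bear on it.

Compound 1 `Cc1cc2c(cc1Cc1ccc(C(=O)NCC3CCCCC3)o1)C(C)(C)CCC2(C)C` is measured in an assay on isolated protein for binding affinity to Gonadotropin-releasing hormone receptor (Homo sapiens) (on this read-out lower numbers stand for stronger inhibition and higher numbers for weaker inhibition), where compound 1 gives 180 nM. For the measured compounds named here, of the two numbers known, this is the highest; the nearest neighbour, compound 2 `Cc1ccc(CNC(=O)c2ccc(Cc3cc4c(cc3C)C(C)(C)CCC4(C)C)o2)cc1`, gives 83 nM, and the only measured step, a 2.2-fold lower number from compound 1 to compound 2 (0.34 log units; beyond the scatter), comes from swapping the cyclohexyl for a 4-methylphenyl group. Compound 3 `Cc1cc2c(cc1Cc1ccc(C(=O)NCC3CCC(CNC(=O)C(F)(F)F)CC3)o1)C(C)(C)CCC2(C)C` keeps the cyclohexyl and instead carries (((trifluoromethyl)carbonyl)amino)methyl in place of hydrogen on a saturated ring carbon. Going by the values given here, no measured step touches this position; the step between compound 1 and compound 2 replaces the whole ring rather than decorating it, so it bears only indirectly on compound 3 and gives no direction. With nothing pointing one way, the number for compound 3 is expected close to that of compound 1, the step of no change at the digits printed from compound 1 to compound 3 (within the scatter) staying within the usual scatter. Compound 3 is therefore estimated at 180 nM, with a range from 60 nM to 540 nM.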

Compound 3, inhibition constant: 66 nM
Compound 3: middle estimate off by 2.7-fold (0.44 log units), on the high side, and the stated range covers the measured number.
By their numbers in this assay, from the lowest: compounds 3 and 2 (each within the scatter of the next); then compound 1.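

For the compounds shown here, until now the only change at this end of the molecule replaced the whole cyclohexyl ring, so nothing showed whether the ring itself could carry a substituent. This result shows that it can: placing (((trifluoromethyl)carbonyl)amino)methyl on a saturated ring carbon, three ring bonds from the ring atom that bears a large group, costs no binding in this assay and instead gives a 2.7-fold lower number from compound 1 to compound 3 (0.44 log units; beyond the scatter), a modest gain from a group of 8 heavy atoms. No measurement here explains this gain.

From the compounds shown here alone, it remains open which part of the new group matters, the trifluoromethyl, the carbonyl or the amide hydrogen. A plain aminomethyl group, a carboxylic acid or a longer chain on the same ring carbon would help separate these parts.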